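Removing the chloro group: expected cytotoxicity of compound 4

This account rests on a few compounds, and the source may have more. Where it says the series, first, only, none or still open, it means among the compounds named here.

Compound 1 `CC(C)CCn1c(Cn2c(=O)n(C3CC3)c3ccncc32)nc2nc(Cl)ccc21`: in an ADME assay on HeLa cells (Homo sapiens) for cytotoxicity, read by ATP content, with a stated time of 3 days (on this read-out lower numbers stand for higher toxicity in this test and higher numbers for lower toxicity in this test), compound 1 gives > 50000 nM, which is a limit of the test and not a number.
Compound 2 `CC(C)(O)CCCn1c(Cn2c(=O)n(C3CC3)c3ccncc32)nc2nc(Cl)ccc21`: in this assay compound 2 gives > 50000 nM, again a limit.
Compound 3 `N#CCCCn1c(Cn2c(=O)n(C3CC3)c3ccncc32)nc2nc(Cl)ccc21`: in this assay compound 3 gives > 50000 nM, again a limit.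

Compound 1 thus stands at the limit where every measured compound sits (the limit of > 50000 nM in this assay, at which 3 of the 3 values shown sit). Compound 4 `CC(C)CCn1c(Cn2c(=O)n(C3CC3)c3ccncc32)nc2ncccc21` differs from it by hydrogen in place of chloro on an aromatic carbon. The measured steps alter the side chain, not the aromatic ring, and their sizes cannot be read: a step that the two limits leave unreadable from compound 1 to compound 2, a step that the two limits leave unreadable from compound 1 to compound 3 and a step that the two limits leave unreadable from compound 2 to compound 3. None of them bears on removing chloro, so no step beyond the scatter is expected in this assay. Compound 4 is therefore estimated at 80000 nM, between 30000 nM and 250000 nM, most likely reported only as a limit, which means an expected step that the limit leaves unreadable from compound 1 to compound 4.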

Compound 4, half-maximal cytotoxic concentration: > 100000 nM
Compound 4 gave a limit, no number (the forecaster's own chance of this, stated with the estimate: 85%); middle value at least 1.2-fold (0.09 log units) away from the limit.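

In this assay compound 4 gives > 100000 nM, a limit and not a number. Compound 1 also sits at a limit, so the step from compound 1 to compound 4 cannot be read. The compounds shown leave open at what concentration any of them would harm these cells.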